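This account rests on a few compounds, and the source may have more. Where it says the series, first, only, none or still open, it means among the compounds named here.

Measured so far in an ADME assay on HepG2 cells (Homo sapiens) for cytotoxicity, with a stated time of 72 h; a higher number here means that more compound is needed for the effect, a lower number that less compound is needed:
- compound 1 `Cc1cc(NC(=O)Nc2ccc(C)c(Cl)c2)c2ccccc2n1`: > 25000 nM
- compound 2 `Cc1cc(NC(=O)Nc2cccc(OC(F)(F)F)c2)c2ccccc2n1`: 13000 nM

Compound 1 reads > 25000 nM, which is a limit of the assay and not a number. Among the compounds with values here, compound 2 gives 13000 nM, the only true number so far.

Compound 3 `Cc1cc(NC(=O)Nc2cccc(Cl)c2)c2ccccc2n1` carries chloro in place of trifluoromethoxy on an aromatic carbon, meta to a large group: chloro in place of trifluoromethoxy on an aromatic carbon. Within the data shown here, no measured step covers this change. A modest rise in this assay is expected, resting only on compound 1, which also carries a chloro group, and its limit of > 25000 nM. The expected step is a 1.4-fold higher number from compound 2 to compound 3 (0.14 log units; within the scatter). For compound 3 the estimated value is 18000 nM, with an expected range of 9000 nM to 30000 nM.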

Compound 3, half-maximal effective concentration: 19000 nM
Beside the measured number, compound 3's estimate is 1.1-fold (0.02 log units) below it; the measured number falls inside the stated range.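

In this assay, chloro in place of trifluoromethoxy on the aromatic carbon meta to a large group gives a 1.5-fold higher number from compound 2 to compound 3 (0.16 log units; within the scatter), so this first measured step at the position does not tell the two groups apart. Hydrogen in place of methyl on an aromatic carbon gives an at least 1.3-fold lower number from compound 1 to compound 3 (0.11 log units; that floor lies within the scatter). That step is only a floor, set by a limit of the assay: the limit of > 25000 nM in this assay, at which 1 of the 3 values shown sits.

Open, from the compounds shown here alone, is whether an amine or a carboxylic acid at this position would give a step beyond the scatter. Going by these compounds, the true size of the methyl step also remains open.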